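Varying the Aryl Amide in a Fluorophenyl Chromone Series

The source may report more compounds than this note shows. Statements on the series, on what has been measured and on what is new or still open speak of the compounds shown alone.

Three amides built on a shared core were tested in a functional assay on MDA-MB-231 cells (Homo sapiens) for antiproliferative activity, read by CCK-8 assay, with a stated time of 72 h; a lower number here means a stronger inhibitor, a higher number a weaker inhibitor. Compound 1 `O=C(Nc1cccc(-c2oc3cc(-c4ccc(F)cc4)ccc3c(=O)c2O)c1)c1ccc(Cl)cc1` gives 12800 nM. Compound 2 `COc1cccc(C(=O)Nc2cccc(-c3oc4cc(-c5ccc(F)cc5)ccc4c(=O)c3O)c2)c1` gives 9160 nM, and compound 3 `Cc1cc(C)cc(C(=O)Nc2cccc(-c3oc4cc(-c5ccc(F)cc5)ccc4c(=O)c3O)c2)c1` gives 11900 nM. Compound 2 has the lowest of the three numbers, but its separation from the others is small: there is a 1.4-fold lower number from compound 1 to compound 2 (0.15 log units; within the scatter), a 1.1-fold lower number from compound 1 to compound 3 (0.03 log units; within the scatter) and a 1.3-fold higher number from compound 2 to compound 3 (0.11 log units; within the scatter), so none of these exchanges of the aryl group on the carbonyl carbon moves the result beyond the scatter.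

Compound 4 `O=C(Nc1cccc(-c2oc3cc(-c4ccc(F)cc4)ccc3c(=O)c2O)c1)c1ccc([N+](=O)[O-])cc1` continues this exchange. Relative to compound 2, the change is 4-nitrophenyl in place of 3-methoxyphenyl on a carbonyl carbon. The three measured steps all bear on it, since each swaps one aryl group for another at the same carbonyl carbon, and each stayed within the scatter. The account therefore expects no step beyond the scatter in this assay for this change either, in no particular direction, giving an estimated 1.1-fold higher number from compound 2 to compound 4 (0.04 log units; within the scatter). Compound 4 is accordingly estimated at 10000 nM, with a range of 5000 nM to 20000 nM.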

Compound 4, half-maximal inhibitory concentration: 14700 nM
The estimate for compound 4 lay 1.5-fold (0.17 log units) below the measured number; the measured number falls inside the stated range.
By their numbers in this assay, from the lowest: compounds 2, 3, 1 and 4 (each within the scatter of the next).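

In this assay there is a 1.6-fold higher number from compound 2 to compound 4 (0.21 log units; within the scatter) and a 1.2-fold higher number from compound 3 to compound 4 (0.09 log units; within the scatter) and a 1.1-fold higher number from compound 1 to compound 4 (0.06 log units; within the scatter) so the fourth aryl group also stays within the scatter of all three earlier ones. The earlier compounds had shown this only for chloro, methoxy and methyl substituents on the aryl ring, and the nitro group now widens that range, including in the direct exchange of nitro for chloro on an aromatic carbon. Nothing measured here explains why these four aryl groups give such similar numbers.

The compounds shown leave open whether any exchange on this carbonyl carbon can move the number beyond the scatter, since all four carry a substituted phenyl ring there. An aminophenyl or carboxyphenyl group, or a saturated alkyl chain in place of the ring, would test this.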